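Mirror Image of a Urea: From Compound 2 to Compound 3

The source may hold more compounds than are shown below. What is called first, only, known or untested is meant among the compounds shown, and "the series" means these compounds.

Compound 1 `CC(=O)c1ccc(NC(=O)N[C@@H](C)c2ccccc2)cc1`: 99%
Compound 2 `C[C@@H](NC(=O)Nc1ccc(I)cc1)c1ccccc1`: 100%

In an ADME assay on the whole organism with Oryza sativa as the target, tested at 0.1 uM (a higher number here means a weaker effect of the compound at the concentration tested, a lower number a stronger effect), compound 1 gives 99% and compound 2 gives 100%. These two numbers lie within the scatter of each other, so compound 2 cannot be set apart from compound 1 on this reading. Compound 3 `C[C@H](NC(=O)Nc1ccc(I)cc1)c1ccccc1` is the unmeasured partner of compound 2: the two compounds have the same atoms and bonds and differ only in configuration as drawn: 1 of 1 stereo elements differ; a stereocentre at a saturated chain carbon is drawn R in compound 2 and S in compound 3. Within the data shown here, no measured pair shows what such a change does in this assay. Because compound 2 gives 100%, near the top of the scale, no step beyond the scatter is expected. The estimated step of a number 2 percentage points lower from compound 2 to compound 3 (within the scatter) is therefore essentially none. Compound 3 is expected to give 98%, in the range 90% to 100%.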

Compound 3, a percentage reported as activity, at one concentration (the size of the read-out at that concentration, not a potency): 99%
Beside the measured number, compound 3's estimate is 1 percentage points below it; measured number inside the range.
By their numbers in this assay, from the lowest: compounds 1, 3 and 2 (each within the scatter of the next).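

Among these compounds, for the first time, a measured pair tests the stereocentre at the saturated chain carbon in this assay, and the change from R to S gives a number 1 percentage points lower from compound 2 to compound 3 (within the scatter). Iodo in place of acetyl on an aromatic carbon gives no change at the digits printed from compound 1 to compound 3 (within the scatter). The first step can be laid on the stereocentre alone, for this reason: the fact that compounds 2 and 3 differ only in the configuration as drawn

As far as these compounds go, all three numbers sit near the top of the scale, so it stays open whether configuration matters in a compound with a stronger effect. From the compounds shown here alone, whether an amine or a carboxylic acid on that aromatic carbon would give a lower number also stays open.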